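The source may hold more compounds than are shown below. What is called first, only, known or untested is meant among the compounds shown, and "the series" means these compounds.

Measured in a physicochemical assay for solubility; on this read-out lower numbers stand for lower solubility and higher numbers for higher solubility:
- compound 1 `O=C(c1ccccc1)N1CCC(NS(=O)(=O)c2cc(S(=O)(=O)c3ccccc3)ccc2C(F)(F)F)CC1`: 12500 nM
- compound 2 `CN(C)c1ccc(C(=O)N2CCC(NS(=O)(=O)c3cc(S(=O)(=O)c4ccccc4)ccc3C(F)(F)F)CC2)cc1`: 50000 nM
- compound 3 `CC(C)(O)CCN1CCC(NS(=O)(=O)c2cc(S(=O)(=O)c3ccccc3)ccc2C(F)(F)F)CC1`: 50000 nM

Compound 3 shares the highest of the three numbers, with no change at the digits printed from compound 2 to compound 3 (within the scatter). Against the remaining member of the series there is a 4.0-fold higher number from compound 1 to compound 3 (0.60 log units; beyond the scatter).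

The next structure is compound 4 `O=C(CC1CCNCC1)N1CCC(NS(=O)(=O)c2cc(S(=O)(=O)c3ccccc3)ccc2C(F)(F)F)CC1`, and the change is ((piperidin-4-yl)methyl)carbonyl in place of 3-hydroxy-3-methylbutyl on an amine nitrogen in a ring. Compound 4 thus returns a carbonyl to the amine nitrogen in a ring, as in the two acylated members of the series. These two give the nearest guide, since both measured steps at this nitrogen start from them. Among them, the aromatic substitution gave a 4.0-fold higher number from compound 1 to compound 2 (0.60 log units; beyond the scatter). A carbonyl at this place therefore does not fix the number: compound 1 gives 12500 nM, while compound 2 gives 50000 nM. Within the data shown here, no measured compound carries ((piperidin-4-yl)methyl)carbonyl, so the estimate is an extrapolation across that span, and it stays close to the higher end.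

The expected step in this assay is a 1.3-fold lower number from compound 3 to compound 4 (0.10 log units; within the scatter), which means none beyond the scatter, although a fall of the modest size seen in this series cannot be excluded. The estimate for compound 4 is 40000 nM, with an expected range of 15000 nM to 60000 nM.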

Compound 4, solubility: 100000 nM
Beside the measured number, compound 4's estimate is 2.5-fold (0.40 log units) below it; measured number above the stated range.
By their numbers in this assay, from the lowest: compound 1; then compounds 2, 3 and 4 (each within the scatter of the next).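

In this assay, (piperidin-4-yl)methyl in place of phenyl on a carbonyl carbon gives an 8.0-fold higher number from compound 1 to compound 4 (0.90 log units; beyond the scatter) with the carbonyl kept, so an acyl group on this amine nitrogen in a ring can reach the upper group of the series without any aromatic ring in it. Against the other two compounds the result gives a 2.0-fold higher number from compound 2 to compound 4 (0.30 log units; within the scatter) and a 2.0-fold higher number from compound 3 to compound 4 (0.30 log units; within the scatter), which leaves the 4-(dimethylamino)benzoyl, ((piperidin-4-yl)methyl)carbonyl and 3-hydroxy-3-methylbutyl groups together within the scatter at this place, with only the benzoyl of compound 1 apart from them. Nothing measured here accounts for these steps.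

Open, from the compounds shown here alone, is whether the ring nitrogen of the piperidin-4-yl group matters, which a cyclohexylmethyl group or a morpholine ring on the same carbonyl carbon would test. Also open, going by these compounds, is whether a small acetyl group or a carboxylic acid on a longer chain at this nitrogen would stay with compounds 2, 3 and 4 or fall back towards compound 1.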